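The source may hold more compounds than are shown below. What is called first, only, known or untested is meant among the compounds shown, and "the series" means these compounds.

Measured compounds:
- compound 1, `COCC(C(=O)N1CCN(c2cccc(C(F)(F)F)c2)CC1)N1C(=O)CCC1=O`, giving 25%
- compound 2, `CC(C(=O)N1CCN(c2ccc(Cl)cc2)CC1)N1C(=O)CCC1=O`, giving 100%
- compound 3, `CCC(C(=O)N1CCN(c2ccccc2Cl)CC1)N1C(=O)CCC1=O`, giving 50%

All three numbers come from a functional assay on the whole organism (strain Swiss) with Mus musculus as the target, in the maximal electroshock model, with a stated time of 0.25 h, at a dose of 300 mg/kg by the intraperitoneal route; on this read-out lower numbers stand for a weaker effect and higher numbers for a stronger effect at the one dose given. Within this small set compound 3 stands second highest: its nearest neighbour is compound 1, whose number is lower by more than the usual scatter, and the furthest is compound 2, whose number is higher by more than the scatter. No two of the measured compounds differ in only one place, so none of these gaps can be pinned to a single structural change.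

Compound 4, `CCC(C(=O)N1CCN(c2ccccc2F)CC1)N1C(=O)CCC1=O`, has not yet been tested in this assay. It differs from compound 3 in one place: fluoro in place of chloro on an aromatic carbon. Cut one bond further out, the same difference reads 2-chlorophenyl to 2-fluorophenyl. Within the data shown here, no measured pair in this set shows the effect of such a swap, so there is nothing here to point firmly in either direction; the step from compound 3 to compound 4 is expected to be small, no change at the digits printed from compound 3 to compound 4 (within the scatter), likely within the scatter. Compound 4 is therefore estimated at 50%, with a range from 25% to 75%.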

Compound 4, a percentage reported as activity, at one dose (the size of the read-out at that dose, not a potency): 100%
Compound 4: the middle estimate sits 50 percentage points below what was measured; measured number outside the range, above it.
By their numbers in this assay, from the lowest: compound 1; then compound 3; then compounds 2 and 4 (each within the scatter of the next).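

Among these compounds, this is the first pair in the set that differs in one place only, so a gap in this assay can now be tied to a single change: fluoro in place of chloro on an aromatic carbon, ortho to a large group, gives a number 50 percentage points higher from compound 3 to compound 4 (beyond the scatter) and nothing else in the structure differs. This place on the ring therefore responds strongly to which of these two atoms it carries, even though the swap leaves the counts of rings, hydrogen-bond donors and acceptors and the net charge as they were. No measurement at hand says why the step is so large.

The compounds shown leave open whether the same swap elsewhere on the ring, or on another core, would give a similar step. They also leave open how this place would respond to a hydrogen, a methoxy group or an amine.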